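A few compounds are considered here, and "the series" means these few. Any claim that something is new, unique, unknown or untested is made for them only; others in the source may bear on it.

Series notes on a functional assay for inhibition of sodium/hydrogen exchanger (Oryctolagus cuniculus); on this read-out higher numbers stand for weaker inhibition and lower numbers for stronger inhibition:
compound 1, `Cc1cc(-c2ccc(Cl)cc2Cl)c(S(C)(=O)=O)cc1C(=O)N=C(N)N`: 42 nM
compound 2, `Cc1cc(Sc2ccncc2)c(S(C)(=O)=O)cc1C(=O)N=C(N)N`: 13 nM
compound 3, `CS(=O)(=O)c1cc(C(=O)N=C(N)N)ccc1Oc1cccnc1`: 76 nM

Compound 3 gives the highest of the three numbers; compound 1 is nearest to it, with a gap within the scatter, and compound 2 is furthest, beyond the scatter. The step to compound 4 `Cc1cc(Oc2cccnc2)c(S(C)(=O)=O)cc1C(=O)N=C(N)N` is methyl in place of hydrogen on an aromatic carbon. For the measured compounds named here, the only measured step, a 3.2-fold lower number from compound 1 to compound 2 (0.51 log units; beyond the scatter), exchanges the aryl group and leaves the methyl untouched, so no measured step bears on this change. Compound 2 carries the methyl and compound 3 does not, but the two also differ in the aryl group, so their gap cannot be assigned to the methyl. For compound 4 a step no larger than the scatter is therefore expected, a 1.7-fold lower number from compound 3 to compound 4 (0.23 log units; within the scatter), in either direction. The estimate for compound 4 is 45 nM, with a range of 15 nM to 130 nM.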

Compound 4, half-maximal inhibitory concentration: 8.8 nM
The estimate for compound 4 lay 5.1-fold (0.71 log units) above the measured number; the measured number lies below the stated range.
By their numbers in this assay, from the lowest: compounds 4 and 2 (each within the scatter of the next); then compounds 1 and 3 (each within the scatter of the next).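

In this assay, for the compounds shown here, methyl on this aromatic carbon, ortho to a group of 6 heavy atoms and para to a methylsulfonyl group, gives an 8.6-fold lower number from compound 3 to compound 4 (0.94 log units; beyond the scatter), the first reading of this change on its own. With the methyl present, (pyridin-3-yl)oxy in place of (pyridin-4-yl)sulfanyl gives a 1.5-fold lower number from compound 2 to compound 4 (0.17 log units; within the scatter), whereas (pyridin-3-yl)oxy in place of 2,4-dichlorophenyl gives a 4.8-fold lower number from compound 1 to compound 4 (0.68 log units; beyond the scatter). Nothing available accounts for the size of the methyl step.

On these data alone, whether this step carries over to the 2,4-dichlorophenyl or (pyridin-4-yl)sulfanyl compounds stays open. So does how an ethyl, a methoxy or a chlorine on this carbon would compare with the methyl.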